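Cyclopropylmethoxy in place of amino on the cyanophenyl ring

The source may report more compounds than this note shows. Statements on the series, on what has been measured and on what is new or still open speak of the compounds shown alone.

Measured so far:
compound 1 `N#Cc1cc(-n2nnc(-c3ccccn3)n2)cc([N+](=O)[O-])c1` 42 nM
compound 2 `N#Cc1cc(N)cc(-n2nnc(-c3ccccn3)n2)c1` 95 nM

In an assay on cell membranes for binding affinity to metabotropic glutamate receptor 5 (Rattus norvegicus) (a lower number here means a stronger inhibitor, a higher number a weaker inhibitor), compound 1 gives 42 nM and compound 2 gives 95 nM. For the measured compounds named here, compound 2 therefore stands at the higher of the two numbers; the only step known is a 2.3-fold higher number from compound 1 to compound 2 (0.35 log units; beyond the scatter).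

Compound 3 `N#Cc1cc(OCC2CC2)cc(-n2nnc(-c3ccccn3)n2)c1` is not yet measured. It differs from compound 2 by cyclopropylmethoxy in place of amino on an aromatic carbon. Going by the values given here, no measured step exchanges the amino group for an ether, so the step from compound 1 to compound 2 is the only point of reference and it does not bear directly on this change. The amino group has so far given the weaker of two numbers, and a return toward the range of compound 1 is plausible; a step of modest size in either direction would not be surprising. Compound 3 is estimated at 60 nM, within 15 nM to 250 nM, which means an expected step of a 1.6-fold lower number from compound 2 to compound 3 (0.20 log units; within the scatter).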

Compound 3, inhibition constant: 271 nM
Compound 3: middle estimate off by 4.5-fold (0.65 log units), on the low side; measured number outside the range, above it.
By their numbers in this assay, from the lowest: compound 1; then compound 2; then compound 3.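

In this assay, this position, meta to a cyano group, accepts cyclopropylmethoxy only at a cost: replacing amino gives a 2.9-fold higher number from compound 2 to compound 3 (0.46 log units; beyond the scatter), and replacing nitro gives a 6.5-fold higher number from compound 1 to compound 3 (0.81 log units; beyond the scatter). For the compounds shown here, both steps lie beyond the scatter, so the three groups now rank from the lowest number to the highest as nitro, amino and cyclopropylmethoxy, with the only group carrying a three-membered ring in last place. Nothing available accounts for this order.

The compounds shown leave open whether the higher number of compound 3 follows from the ether oxygen or from the cyclopropyl ring, which a methoxy group and an all-carbon cyclopropylethyl chain could separate. Also open, on these data alone, is how a halogen such as chlorine, or an amide, would rank at this position against the nitro group of compound 1 at 42 nM.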